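Thiophen-3-yl in place of 4-methylphenyl: working notes

The source may report more compounds than this note shows. Statements on the series, on what has been measured and on what is new or still open speak of the compounds shown alone.

compound 1 `Cc1ccc(-c2nc3ccccn3c2Sc2ccccc2)cc1` gives > 100000 nM
compound 2 `c1ccc(Sc2c(-c3cccc4ccccc34)nc3ccccn23)cc1` gives > 100000 nM
compound 3 `c1ccc(Sc2c(-c3ccccc3)nc3ccc(-c4ccccc4)cn23)cc1` gives > 100000 nM

All three readings come from an ADME assay on HEK293 cells (Homo sapiens) for inhibition, read by MTT assay, with a stated time of 48 h (a higher number here means a weaker inhibitor, a lower number a stronger inhibitor), and none of them is a number. In this assay compound 1 gives > 100000 nM, which is a limit of the assay. Compound 2 also reads only as a limit. Compound 3 also reads only as a limit. Going by the values given here, the position of compound 1 is therefore described only by the limit of > 100000 nM in this assay, at which 3 of the 3 values shown sit, and no pair of measured compounds yields a step.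

The next compound is compound 4 `c1ccc(Sc2c(-c3ccsc3)nc3ccccn23)cc1`, which has thiophen-3-yl in place of 4-methylphenyl on an aromatic carbon of the five-membered aromatic ring with 2 nitrogen (thiophen-3-yl in place of 4-methylphenyl on an aromatic carbon). The phenylsulfanyl group and the rest of the core of compound 1 stay as they are.

Among the compounds with values here, the expectation rests on compound 1 with its limit of > 100000 nM, as the series offers no measured step to scale from. No change beyond the scatter is expected in this assay, and the expected step is a number no higher from compound 1 to compound 4 (the limit leaves the size open) in neither direction in particular. A reading at the limit of the assay is the likeliest outcome. For compound 4 the estimate is 100000 nM, with an expected range from 30000 nM to 150000 nM.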

Compound 4, half-maximal inhibitory concentration: 91700 nM
Estimate against measurement, compound 4: 1.1-fold (0.04 log units) above; measured number inside the range.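

Thiophen-3-yl on this aromatic carbon, in place of 4-methylphenyl, gives the first reading in this assay that is a number and not a limit, with compound 4 at 91700 nM. The change swaps a six-membered aromatic ring of carbon only for a five-membered aromatic ring with 1 hetero atom, and the step reads an at least 1.0-fold lower number from compound 1 to compound 4 (0.03 log units; that floor lies within the scatter); this figure is only a floor, so the true size of the step cannot be read from it, and the result shows neither a gain nor the absence of one. Compound 4 therefore cannot be ranked against the other compounds of the series: the limit of > 100000 nM in this assay, at which 3 of the 4 values shown sit.

The compounds shown leave open how large the step from 4-methylphenyl to thiophen-3-yl really is, and whether any aromatic ring at this carbon can bring the reading clearly away from the limit. They also leave open what an amine or a carboxylic acid carried at this carbon, in place of thiophen-3-yl, would do to the reading in this assay.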